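Fluorinated aryl ethers of an iminosugar: cytotoxicity in kidney cells

A few compounds are considered here, and "the series" means these few. Any claim that something is new, unique, unknown or untested is made for them only; others in the source may bear on it.

Compound 1, `OC[C@@H]1[C@@H](O)[C@H](O)[C@@H](O)CN1CC/C=C/CCOc1cc(F)ccc1F`, in an ADME assay on MDBK cells (Bos taurus) for cytotoxicity, read by MTT assay (on this read-out higher numbers stand for lower toxicity in this test and lower numbers for higher toxicity in this test), gives > 500000 nM, which is a limit of the assay rather than a number.
Compound 2, `OC[C@@H]1[C@@H](O)[C@H](O)[C@@H](O)CN1CCCCCCOc1cc(F)ccc1F`, in this assay gives > 500000 nM, again a limit of the assay.
Compound 3, `OC[C@@H]1[C@@H](O)[C@H](O)[C@@H](O)CN1CCCCCCOc1ccc(C(F)(F)F)cc1`, in this assay gives > 500000 nM, also a limit of the assay.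

Compound 2 therefore stands only at a limit in this assay, and it is not alone there: the limit of > 500000 nM in this assay, at which 3 of the 3 values shown sit. No step between measured compounds is available, so nothing among these three separates one from another on this read-out.

Compound 4, `OC[C@@H]1[C@@H](O)[C@H](O)[C@@H](O)CN1CCCCCCOc1c(F)cc(F)cc1F`, has not yet been measured in this assay. It differs from compound 2 in one place: 2,4,6-trifluorophenyl in place of 2,5-difluorophenyl on an oxygen on a saturated carbon. Because the limit of > 500000 nM in this assay, at which 3 of the 3 values shown sit, holds for every compound seen so far, the step in this assay is expected to be none beyond the scatter, and compound 4 is expected to be reported as a limit as well. The estimate for compound 4 in this assay is 500000 nM, with a range from 250000 nM to 1000000 nM. The expected step in this assay is a number no higher from compound 2 to compound 4 (the limit leaves the size open).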

Compound 4, half-maximal cytotoxic concentration: > 500000 nM
Compound 4 ended at the assay's limit (the forecaster's own chance of this, stated with the estimate: 90%); the middle value lies on the limit itself.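

Compound 2 and compound 4 both stand at a limit in this assay, so no step can be read between them: the limit of > 500000 nM in this assay, at which 4 of the 4 values shown sit.

The compounds shown leave open whether 2,4,6-trifluorophenyl in place of 2,5-difluorophenyl alters this read-out at all, and where any of the four would give an actual number.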